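Amide aryl swap where every value sits at the limit

The source may report more compounds than this note shows. Statements on the series, on what has been measured and on what is new or still open speak of the compounds shown alone.

Compound 1, `O=C(Nc1ccccc1)c1cccc(/C=C2\CC(=O)N(c3ccccc3)C2=O)c1`: in an ADME assay on NCM460 cells (Homo sapiens) for cytotoxicity, read by MTT assay, with a stated time of 72 h (a higher number here means a weaker inhibitor, a lower number a stronger inhibitor), compound 1 gives > 100000 nM, which is a limit of the assay.
Compound 2, `CCc1ccc(NC(=O)c2cccc(/C=C3\CC(=O)N(c4ccccc4)C3=O)c2)cc1`: in this assay compound 2 gives > 100000 nM, a limit.
Compound 3, `Cc1ccc(N2C(=O)C/C(=C\c3cccc(C(=O)Nc4cccc(F)c4)c3)C2=O)cc1`: in this assay compound 3 gives > 100000 nM, a limit.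

Compound 2 therefore stands at a limit in this assay, and the two further values shown are limits as well, so that the limit of > 100000 nM in this assay, at which 3 of the 3 values shown sit, describes the whole set. The new member is compound 4, `Cc1cccc(NC(=O)c2cccc(/C=C3\CC(=O)N(c4ccccc4)C3=O)c2)c1`, which differs from compound 2 by 3-methylphenyl in place of 4-ethylphenyl on an amide-type nitrogen, the 4-ethylphenyl group leaving and the 3-methylphenyl group entering on an amide-type nitrogen whose other neighbour is a carbonyl carbon. Among the measured compounds shown here, the only measured step that touches this amide aryl is a step that the two limits leave unreadable from compound 1 to compound 2, and its size cannot be read because both ends are limits. Nothing in the data gives a readable change for varying this aryl, so no step beyond the scatter is expected here, and compound 4 is expected to be reported as a limit too. For compound 4 the estimate in this assay is 150000 nM, ranging from 60000 nM to 400000 nM. The step this implies, a step that the limit leaves unreadable from compound 2 to compound 4, is an expectation of essentially no change.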

Compound 4, half-maximal inhibitory concentration: > 100000 nM
Compound 4: only a limit was reported; the forecaster's own chance of this, stated with the estimate: 85%; the middle value does not contradict the limit.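

In this assay compound 4 gives > 100000 nM, a limit, so its steps from compound 1 and compound 2 cannot be read. The compounds shown leave open whether changing the aryl group on the amide nitrogen alters the value at all: the limit of > 100000 nM in this assay, at which 4 of the 4 values shown sit.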